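Isobutyl in place of 1-methyl-1H-pyrazol-5-yl on the carbonyl carbon

A few compounds are considered here, and "the series" means these few. Any claim that something is new, unique, unknown or untested is made for them only; others in the source may bear on it.

Within the data shown here, in a functional assay on HUVEC cells (Homo sapiens) for antiproliferative activity, read by WST assay, with a stated time of 5 days (a higher number here means a weaker inhibitor, a lower number a stronger inhibitor), compound 2 `Cc1ccc(Oc2ccc3nc(NC(=O)C4CC4)nn3c2)cc1NC(=O)c1ccnn1C` gives 9.9 nM as the higher of the two numbers so far, while compound 1 `Cc1cc(C(=O)Nc2cc(Oc3ccc4nc(NC(=O)C5CC5)nn4c3)ccc2C)n(C)n1` gives 1.3 nM on the same core. The next change leads to compound 3 `Cc1ccc(Oc2ccc3nc(NC(=O)C4CC4)nn3c2)cc1NC(=O)CC(C)C` and puts isobutyl in place of 1-methyl-1H-pyrazol-5-yl on a carbonyl carbon so that no ring remains in this group. Among the measured compounds shown here, only one measured step bears on this: a 7.6-fold higher number from compound 1 to compound 2 (0.88 log units; beyond the scatter) for hydrogen in place of methyl on an aromatic carbon, which lies beyond the scatter. For the measured compounds named here, that step touched the leaving group only in part, and no measured compound lacks that group, so the guide is weak. The expected size is a 3.0-fold higher number from compound 2 to compound 3 (0.48 log units; beyond the scatter) as a rough estimate. In this assay compound 3 is expected at 30 nM with a range from 8 nM to 120 nM as the working estimate.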

Compound 3, half-maximal inhibitory concentration in the HUVEC assay: 56 nM
Beside the measured number, compound 3's estimate is 1.9-fold (0.27 log units) below it; low and high end bracket the measured number.
By their numbers in the HUVEC assay, from the lowest: compound 1; then compound 2; then compound 3.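

In the HUVEC assay, isobutyl in place of 1-methyl-1H-pyrazol-5-yl on the carbonyl carbon gives a 5.7-fold higher number from compound 2 to compound 3 (0.75 log units; beyond the scatter), and isobutyl in place of 1,3-dimethyl-1H-pyrazol-5-yl gives a 43-fold higher number from compound 1 to compound 3 (1.63 log units; beyond the scatter), so among these three compounds both pyrazolyl groups give lower numbers than the ring-free isobutyl. In a physicochemical assay for solubility, measured as kinetic solubility, at pH 6.8 (a lower number here means a less soluble compound, a higher number a more soluble compound), the same change from the 1-methyl-1H-pyrazol-5-yl group reads an at least 6.6-fold lower number from compound 2 to compound 3 (0.82 log units; beyond the scatter), with the lower solubility reading going with isobutyl: the limit of > 80 ug/mL in the physicochemical assay, at which 1 of the 2 values shown sits. In the physicochemical assay compound 2 gives > 80 ug/mL, which is a limit and not a number, so the full size of that step stays unfixed. In the physicochemical assay compound 3 gives 12 ug/mL.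

Isobutyl is the only ring-free group shown at this position, so the loss cannot yet be assigned to removing the ring or to isobutyl itself. A phenyl ring, a pyridine ring or a longer chain on this carbonyl carbon would help separate the two.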